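Extending a side chain: from formyl to carboxy

The source may hold more compounds than are shown below. What is called first, only, known or untested is meant among the compounds shown, and "the series" means these compounds.

Compound 1 `Cn1c(Cc2nn(C)c(=O)c3ccccc23)nnc1SCC(=O)Nc1ccc(Cl)cc1Cl` gives 7700 nM in an assay on NK92 cells for inhibition of interleukin-2 (Homo sapiens), read by AlphaScreen, with stated times of 30 min and 1 h; on this read-out higher numbers stand for weaker inhibition and lower numbers for stronger inhibition.
Compound 2 `CCOC(CCn1c(Cc2nn(C)c(=O)c3ccccc23)nnc1SCCCCCCCC(=O)Nc1ccc(Cl)cc1Cl)OCC` reaches only the limit of this assay, > 30000 nM.
Compound 3 `Cn1nc(Cc2nnc(SCC(=O)Nc3ccc(Cl)cc3Cl)n2CCC=O)c2ccccc2c1=O` gives 8600 nM in this assay.

Among the compounds that give a number, compound 3 stands at the highest value, but its nearest neighbour is compound 1, and the step of a 1.1-fold higher number from compound 1 to compound 3 (0.05 log units; within the scatter) lies within the scatter of this assay. The limit reached by compound 2 is a limit only and not a number (the limit of > 30000 nM in this assay, at which 1 of the 3 values shown sits).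

Compound 4 `Cn1nc(Cc2nnc(SCC(=O)Nc3ccc(Cl)cc3Cl)n2CCC(=O)O)c2ccccc2c1=O` differs from compound 3 in one place: hydroxy in place of hydrogen on a carbonyl carbon. Cut one bond further out, the same change reads formyl to carboxy on the 2-formylethyl chain that hangs from the aromatic nitrogen of the shared core.

Among the compounds with values here, only one measured step bears on this move. It is the step from compound 1 to compound 3, which added the formylmethyl chain to that same nitrogen and left the value unchanged within the scatter. Turning the formyl end of that chain into a carboxy end is therefore expected to change little, and compound 4 is estimated to give 10000 nM, between 4000 nM and 25000 nM, which means an expected step of a 1.2-fold higher number from compound 3 to compound 4 (0.07 log units; within the scatter).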

Compound 4, half-maximal inhibitory concentration: > 30000 nM
Compound 4 was reported as a limit; the forecaster's own chance of this, stated with the estimate: 15%; middle value at least 3.0-fold (0.47 log units) from the limit.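

A single hydroxy in place of hydrogen on a carbonyl carbon, at the end of the 2-formylethyl chain, does matter in this assay: it gives an at least 3.4-fold higher number from compound 3 to compound 4 (0.54 log units; beyond the scatter). Set against compound 1, whose aromatic nitrogen carries no such chain, the carboxy end gives an at least 3.8-fold higher number from compound 1 to compound 4 (0.59 log units; beyond the scatter), whereas the formyl end gave a 1.1-fold higher number from compound 1 to compound 3 (0.05 log units; within the scatter), so among these three compounds the chain alone leaves the reading in place and the group at its end is what separates them. The reading for compound 4 is a limit of the assay and not a number, so both steps give only a lower bound on the size of the change: the limit of > 30000 nM in this assay, at which 2 of the 4 values shown sit.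

From the compounds shown here alone, how far the carboxy end really lies from the formyl end stays open, as does the question of whether the loss belongs to the added hydroxy itself or to the carboxy group as a whole. A methyl ester, a primary amide or an amine at the end of the same chain could show which end groups behave like formyl and which like carboxy, and a longer chain ending in carboxy could show whether the distance from the core plays any part.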